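The source may hold more compounds than are shown below. What is called first, only, known or untested is meant among the compounds shown, and "the series" means these compounds.

Measured so far in a functional assay with Alpha-1A adrenergic receptor (Homo sapiens) as the target, read by calcium flux; a lower number here means a smaller maximal response, a higher number a larger maximal response:
compound 1 `c1cncc(-c2ccccc2OCC2=NCCN2)c1` gives 109%
compound 2 `c1ccc(-c2cc[nH]n2)c(OCC2=NCCN2)c1` gives 119%
compound 3 `c1ccc(-c2ncc[nH]2)c(OCC2=NCCN2)c1` gives 122%

Compound 1 stands lowest of the three: compound 2 lies within the scatter of it, while compound 3 sits beyond the scatter, as a number 13 percentage points higher from compound 1 to compound 3 (beyond the scatter) shows. Compound 4 `Cc1ccoc1-c1ccccc1OCC1=NCCN1` has not yet been measured. It differs from compound 1 in one place: 3-methylfuran-2-yl in place of pyridin-3-yl on an aromatic carbon. Going by the values given here, two measured steps bear on this change, both of them also replacing pyridin-3-yl with a five-membered aromatic ring: a number 10 percentage points higher from compound 1 to compound 2 (within the scatter) and a number 13 percentage points higher from compound 1 to compound 3 (beyond the scatter). Both moved slightly upward, one within and one just beyond the scatter. A similar small upward step, or none beyond the scatter, is therefore expected for compound 4 in this assay, namely a number 7 percentage points higher from compound 1 to compound 4 (within the scatter). The estimate for compound 4 is 116%, with a range from 102% to 130%.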

Compound 4, largest response reached (reported as maximum), in percent of the reference or control that the assay uses: 99%
The estimate for compound 4 lay 17 percentage points above the measured number, and the stated range ends above it.
By their numbers in this assay, from the lowest: compounds 4, 1, 2 and 3 (each within the scatter of the next, the first and the last beyond it).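

In this assay, a five-membered aromatic ring at this position does not by itself go with a larger maximal response: 3-methylfuran-2-yl gives a number 10 percentage points lower from compound 1 to compound 4 (within the scatter), so it cannot be told apart from pyridin-3-yl. The same group gives a number 20 percentage points lower from compound 2 to compound 4 (beyond the scatter) and a number 23 percentage points lower from compound 3 to compound 4 (beyond the scatter), so the identity of the five-membered ring matters here, not just its size. No measurement at hand gives a reason for these gaps.

The compounds shown leave the methyl and the furan oxygen unseparated. An unsubstituted furan-2-yl and a 3-methylthiophen-2-yl would test each in turn.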